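The source may hold more compounds than are shown below. What is called first, only, known or untested is meant among the compounds shown, and "the series" means these compounds.

Compound 1 `O=C(Nc1cccc(-n2cc(-c3ccncc3)c(-c3cc(O)cc(Cl)c3)n2)c1)Nc1ccc(Cl)c(C(F)(F)F)c1` gives 93%
Compound 2 `O=C(Nc1cccc(-n2cc(-c3ccncc3)c(-c3cc(O)cc(Cl)c3)n2)c1)Nc1ccc(Cl)c(Cl)c1` gives 98%

In a functional assay on SF-268 cells (Homo sapiens) for inhibition, read by sulforhodamine B assay, with a stated time of 48 h, tested at 0.1 uM (on this read-out higher numbers stand for a weaker effect at the one concentration tested and lower numbers for a stronger effect), compound 1 stands lowest of the two numbers, and its nearest neighbour is compound 2, the step of a number 5 percentage points higher from compound 1 to compound 2 (within the scatter) lying within the scatter. Compound 3 `COc1cc(Cl)cc(-c2nn(-c3cccc(NC(=O)Nc4ccc(Cl)c(C(F)(F)F)c4)c3)cc2-c2ccncc2)c1` differs from compound 1 in one place: methyl in place of hydrogen on an oxygen on an aromatic ring. Among the compounds with values here, no measured step touches the hydroxy group; the only step seen changes a group elsewhere and stays within the scatter, so it offers little guidance. For compound 3 the expected step is a number 2 percentage points higher from compound 1 to compound 3 (within the scatter), nothing beyond the scatter. The estimate for compound 3 in this assay is 95%, from 80% to 105%.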

Compound 3, a percentage reported as activity, at one concentration (the size of the read-out at that concentration, not a potency): 90%
The estimate for compound 3 lay 5 percentage points above the measured number, within the range that was stated.
By their numbers in this assay, from the lowest: compounds 3, 1 and 2 (each within the scatter of the next).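

In this assay the change from hydroxy to methoxy on the aromatic ring gives a number 3 percentage points lower from compound 1 to compound 3 (within the scatter) and so, at this one concentration, replacing the hydrogen on this oxygen with methyl produces no readable difference. Within the data shown here, the earlier step concerned a different part of the molecule, so this is the first look at this position. Nothing measured here offers an explanation for the result. From the compounds shown here alone, whether an ethyl group or a longer chain on this oxygen, or an amine in place of the hydroxy group, would give a step beyond the scatter stays open. A single concentration also leaves open whether the effect of these compounds would be stronger or weaker at any other concentration.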